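Urea in place of benzamide on the shared core

This account rests on a few compounds, and the source may have more. Where it says the series, first, only, none or still open, it means among the compounds named here.

Compound 1 `O=C(Nc1cccc(-n2cc(-c3ccncc3)c(-c3ccc(Cl)c(O)c3)n2)c1)Nc1ccc(Cl)c(Cl)c1`: 3570 nM in a functional assay on NCI-H460 cells (Homo sapiens) for inhibition, read by sulforhodamine B assay, with a stated time of 48 h; a lower number here means a stronger inhibitor of growth, a higher number a weaker inhibitor of growth
Compound 2 `COc1cc(-c2nn(-c3cccc(NC(=O)c4cccc(C(F)(F)F)c4)c3)cc2-c2ccncc2)ccc1Cl`: 9270 nM
Compound 3 `COc1cc(-c2nn(-c3cccc(NC(=O)c4ccccc4)c3)cc2-c2ccncc2)ccc1Cl`: only the assay limit, > 100000 nM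

Compound 3 sits at the weak end of this assay; its value is a limit and not a number, the line the limit of > 100000 nM in this assay, at which 1 of the 3 values shown sits, marking where it stands. The change to compound 4 `COc1cc(-c2nn(-c3cccc(NC(=O)Nc4ccc(Cl)c(Cl)c4)c3)cc2-c2ccncc2)ccc1Cl` is (3,4-dichlorophenyl)amino in place of phenyl on a carbonyl carbon. Among the measured compounds shown here, the only measured step touching the amide end is an at least 10-fold higher number from compound 2 to compound 3 (1.03 log units; beyond the scatter), showing that this position moves growth inhibition strongly. Compound 1 carries the same (3,4-dichlorophenyl)carbamoyl group and gives 3570 nM. A large drop in the concentration for total growth inhibition is therefore expected: an at least 22-fold lower number from compound 3 to compound 4 (1.34 log units; beyond the scatter). Compound 4 is estimated at 4500 nM, within a range of 1500 nM to 15000 nM.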

Compound 4, concentration for total growth inhibition: > 50000 nM
Compound 4 ended at the assay's limit (the forecaster's own chance of this, stated with the estimate: 10%); middle value at least 11-fold (1.04 log units) from the limit.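

Compound 4 is a limit and not a number, and its step from compound 3 cannot be read: the limit of > 50000 nM in this assay, at which 1 of the 4 values shown sits. The (3,4-dichlorophenyl)carbamoyl group does not hold growth inhibition on its own, since methyl on the oxygen of the aromatic ring gives an at least 14-fold higher number from compound 1 to compound 4 (1.14 log units; beyond the scatter). With that methyl kept, the group also compares poorly with the 3-(trifluoromethyl)phenyl amide, giving an at least 5.3-fold higher number from compound 2 to compound 4 (0.73 log units; beyond the scatter).

Open, as far as these compounds go, is how the 3-(trifluoromethyl)phenyl amide responds to hydrogen in place of that methyl. Also open, from the compounds shown here alone, is whether an amine or an ethyl ether on that aromatic carbon would read like the hydroxyl or the methyl ether.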